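The source may hold more compounds than are shown below. What is called first, only, known or untested is meant among the compounds shown, and "the series" means these compounds.

In an ADME assay on BJ cells (Homo sapiens) for cytotoxicity, read by MTT assay, with a stated time of 72 h (a lower number here means that less compound is tolerated, a higher number that more compound is tolerated), compound 1 `OC[C@H]1O[C@@H](n2cc(F)c3c(-c4ccccc4)ncnc32)[C@H](O)[C@@H]1O` gives > 50000 nM, which is a limit of the assay and not a number. Compound 3 `OC[C@H]1O[C@@H](n2cc(Cl)c3c(-c4ccccc4)ncnc32)[C@H](O)[C@@H]1O` gives 44500 nM, the higher of the two actual numbers and far from compound 2 `OC[C@H]1O[C@@H](n2cc(F)c3c(-c4ccco4)ncnc32)[C@H](O)[C@@H]1O` at 310 nM. The next compound, compound 4 `OC[C@H]1O[C@@H](n2cc(Cl)c3c(-c4ccco4)ncnc32)[C@H](O)[C@@H]1O`, keeps the chloro group of compound 3 and changes one substituent: furan-2-yl in place of phenyl on an aromatic carbon. Within the data shown here, two measured steps bear on this. The same swap of phenyl for furan-2-yl, made with fluoro in place of chloro, was large: an at least 160-fold lower number from compound 1 to compound 2 (2.20 log units; beyond the scatter). The exchange of fluoro for chloro gave an at least 1.1-fold lower number from compound 1 to compound 3 (0.05 log units; that floor lies within the scatter), whose floor lies within the scatter, so the halogen offers no reason to expect a different outcome. Among the measured compounds shown here, a large fall in this assay is therefore expected, with compound 4 landing close to compound 2, though only one earlier swap supports this. The expected change is a 150-fold lower number from compound 3 to compound 4 (2.17 log units; beyond the scatter). For compound 4 the estimated value is 300 nM, with an expected range from 80 nM to 1500 nM.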

Compound 4, half-maximal cytotoxic concentration: 37300 nM
For compound 4 the middle estimate is 120-fold (2.09 log units) below the measured one; measured number outside the range, above it.
By their numbers in this assay, from the lowest: compound 2; then compounds 4 and 3 (each within the scatter of the next). At a limit, above all of these: compound 1.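

With chloro on the shared core, furan-2-yl in place of phenyl on this aromatic carbon leaves the number in this assay essentially unchanged, a 1.2-fold lower number from compound 3 to compound 4 (0.08 log units; within the scatter), so the large fall seen with fluoro does not carry over and the outcome of this swap depends on the halogen: the same change on two cores in this assay, an at least 160-fold lower number (2.20 log units; beyond the scatter) from compound 1 to compound 2 and a 1.2-fold lower number (0.08 log units; within the scatter) from compound 3 to compound 4, at least 130-fold (2.13 log units) apart, beyond the scatter of two such steps

Read the other way, chloro in place of fluoro is large when furan-2-yl is present, a 120-fold higher number from compound 2 to compound 4 (2.08 log units; beyond the scatter), whereas with phenyl that exchange gives only a floor: the same change on two cores in this assay, an at least 1.1-fold lower number (0.05 log units; that floor lies within the scatter) from compound 1 to compound 3 and a 120-fold higher number (2.08 log units; beyond the scatter) from compound 2 to compound 4, at least 130-fold (2.13 log units) apart, beyond the scatter of two such steps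

Among the compounds shown, the low number therefore belongs to compound 2 alone, the one that pairs fluoro with furan-2-yl.

As far as these compounds go, what remains open is whether that pairing is specific to these two groups, or whether thiophen-2-yl or an amine on this aromatic carbon would also give a low number alongside fluoro. Also open, from the compounds shown here alone, is how bromo or methyl in place of the halogen would behave with furan-2-yl.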